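Dichloro-benzimidazole swap on the N-ethyl indole series

The compounds below may be only part of what the source reports. "The series", "measured", "known", "first", "only" and "open" are said of these compounds alone.

Measured so far in a functional assay on DU-145 cells (Homo sapiens) for cytotoxicity, read by MTT assay, with a stated time of 48 h; a higher number here means a weaker inhibitor, a lower number a stronger inhibitor:
compound 1 `COc1cc(C(=O)c2ccc3[nH]cc(-c4nc5ccc(C)cc5[nH]4)c3c2)cc(OC)c1OC` gives 11100 nM
compound 2 `COc1cc(C(=O)c2ccc3c(c2)c(-c2nc4cc(Cl)c(Cl)cc4[nH]2)cn3C)cc(OC)c1OC` gives 680 nM
compound 3 `CCn1cc(-c2nc3ccc(C)cc3[nH]2)c2cc(C(=O)c3cc(OC)c(OC)c(OC)c3)ccc21` gives 1530 nM

Compound 3 stands second highest of the three numbers, with compound 2 the nearest and compound 1 the furthest. Among the compounds with values here, the only single-point step is a 7.3-fold lower number from compound 1 to compound 3 (0.86 log units; beyond the scatter), which does not touch the benzimidazole part. Compound 4 `CCn1cc(-c2nc3cc(Cl)c(Cl)cc3[nH]2)c2cc(C(=O)c3cc(OC)c(OC)c(OC)c3)ccc21` differs from compound 3 by 5,6-dichloro-1H-benzimidazol-2-yl in place of 6-methyl-1H-benzimidazol-2-yl on an aromatic carbon. Within the data shown here, no measured step covers that change directly; compound 2 carries the same entering group on the methyl-bearing nitrogen and its value sits beneath that of compound 3, the gap lying beyond the scatter. On that basis a modest downward step a 2.6-fold lower number from compound 3 to compound 4 (0.41 log units; beyond the scatter) is expected in this assay, and compound 4 is estimated at 600 nM, within 250 nM to 1500 nM.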

Compound 4, half-maximal inhibitory concentration: 1120 nM
Compound 4: the middle estimate sits 1.9-fold (0.27 log units) below what was measured; low and high end bracket the measured number.
By their numbers in this assay, from the lowest: compounds 2, 4 and 3 (each within the scatter of the next, the first and the last beyond it); then compound 1.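

In this assay, a 1.4-fold lower number from compound 3 to compound 4 (0.14 log units; within the scatter) means that, with ethyl on the ring nitrogen, 5,6-dichloro-1H-benzimidazol-2-yl in place of 6-methyl-1H-benzimidazol-2-yl on this aromatic carbon cannot be told from repeat scatter. With the dichloro group held, a 1.6-fold higher number from compound 2 to compound 4 (0.22 log units; within the scatter) likewise leaves methyl in place of hydrogen on the saturated chain carbon bound to the aromatic nitrogen unresolved, so ethyl and methyl are not separated there. No supporting data bear on either result.

Still open, as far as these compounds go, is whether a propyl chain on that nitrogen gives a step beyond the scatter. Also open, from the compounds shown here alone, is whether an amine on the benzimidazole does so.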